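Replacing a Methyl with an Oxazole on the Amide Nitrogen

The source may hold more compounds than are shown below. What is called first, only, known or untested is meant among the compounds shown, and "the series" means these compounds.

Measured compounds:
Compound 1 `Cc1ccc(OCC(=O)N(C)Cc2cccs2)cc1`: 400 nM
Compound 2 `CCN(Cc1cccs1)C(=O)/C=C/c1ccc(C)cc1`: 2 nM

In an assay on HEK293 cells for agonist activity at transient receptor potential cation channel subfamily M member 8 (Homo sapiens), read by fluorescence and calcium flux, with a stated time of 15 min (a higher number here means that more compound is needed for the effect, a lower number that less compound is needed), compound 1 gives 400 nM, the highest of the two numbers; compound 2 gives 2 nM, a much lower number, beyond the scatter. Compound 3 `Cc1ccc(OCC(=O)N(Cc2cccs2)c2ccon2)cc1` differs from compound 1 in one place: 1,2-oxazol-3-yl in place of methyl on an amide-type nitrogen. Within the data shown here, no pair differing in just this way has been measured, so the step has to be guessed. A modest decrease in the number is expected, estimated as a 2.2-fold lower number from compound 1 to compound 3 (0.35 log units; beyond the scatter). For compound 3 the expected value is 180 nM, within 40 nM to 900 nM.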

Compound 3, half-maximal effective concentration: 2 nM
Compound 3: middle estimate off by 90-fold (1.95 log units), on the high side, outside the stated range (below it).
By their numbers in this assay, from the lowest: compounds 2 and 3 (each within the scatter of the next); then compound 1.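

Compound 3 shows that the amide-type nitrogen is a highly sensitive place in this structure: putting 1,2-oxazol-3-yl in place of methyl gives a 200-fold lower number from compound 1 to compound 3 (2.30 log units; beyond the scatter). The entering group adds a five-membered aromatic ring and hydrogen-bond acceptors, neither of which methyl has. Nothing available explains the size of this step.

Going by these compounds, whether any ring on this nitrogen would give a similar step, for example a plain phenyl ring, remains open. So does the effect of a longer chain, such as propyl, at the same place.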